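Trading a Propylamino Group for a Carboxy Group

This account rests on a few compounds, and the source may have more. Where it says the series, first, only, none or still open, it means among the compounds named here.

The measurements come from a functional assay for antagonist activity at transient receptor potential cation channel subfamily V member 1 (Homo sapiens), read by FLIPR; on this read-out higher numbers stand for weaker inhibition and lower numbers for stronger inhibition. Two compounds share a core in which an amide links two aromatic rings, one of them joined to a ring that holds a nitrogen. Compound 1, `O=C(Nc1ccccc1)c1ccc(-c2ncccc2C(F)(F)F)cc1`, carries a trifluoromethyl group on that ring. In this assay compound 1 gives > 4000 nM, which is a limit of the assay rather than a number; (the limit of > 4000 nM in this assay, at which 1 of the 2 values shown sits). Compound 2, `CCCNc1cccnc1-c1ccc(C(=O)Nc2ccc(C(C)(C)C)cc2)cc1`, carries a propylamino group in the same region and a tert-butyl group on the amide-bearing ring. In this assay compound 2 gives 158 nM, the only actual number shown so far.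

Compound 3, `CC(C)(C)c1ccc(NC(=O)c2ccc(-c3ncccc3C(=O)O)cc2)cc1`, keeps the tert-butyl group but makes one change: carboxy in place of propylamino on an aromatic carbon. Within the data shown here, no measured pair of compounds follows this change, so what it does is open. The expectation is that the step from compound 2 to compound 3 will weaken inhibition well beyond the scatter, by about a 19-fold higher number from compound 2 to compound 3 (1.28 log units; beyond the scatter). Compound 3 is therefore estimated at 3000 nM, within a range from 500 nM to 20000 nM.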

Compound 3, half-maximal inhibitory concentration: > 4000 nM
Compound 3 gave a limit, no number; the forecaster's own chance of this, stated with the estimate: 45%; at least 1.3-fold (0.12 log units) between middle value and limit.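

On an aromatic carbon two atoms from the ring nitrogen, carboxy in place of propylamino gives an at least 25-fold higher number from compound 2 to compound 3 (1.40 log units; beyond the scatter) in this assay. Among these compounds, this is the first comparison here between two compounds that differ in only one place, so it ties a large loss of inhibition to this single change, with the tert-butyl group and the rest of the molecule left as they were. Among the compounds shown here, since compound 3 gives no actual number, the step sets only a minimum size, and compound 2 remains the only compound with a measured number, the others resting on the assay's limit: the limit of > 4000 nM in this assay, at which 2 of the 3 values shown sit.

This one pair cannot separate what the carboxy group brings from what the departing propylamino group took away, so the compounds shown do not tell how a plain amine, a methyl ester, an amide or a longer chain on the same carbon would read. They also leave open how far inhibition could improve on compound 2, since no change shown here gives a stronger result.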